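Amine-bearing ether variation on the sulfonamide series

The source may hold more compounds than are shown below. What is called first, only, known or untested is meant among the compounds shown, and "the series" means these compounds.

Three compounds share one core and differ only in the amine-bearing group on the oxygen on the aromatic ring. Compound 1 `CC(=O)SCC(=O)c1ccc(NS(=O)(=O)c2ccc(OCCCCN(C)C)cc2)nc1` carries a 4-(dimethylamino)butyl group and in a functional assay on HCT-116 cells (Homo sapiens) for cytotoxicity (a lower number here means that less compound is needed, a higher number that more compound is needed for the effect), compound 1 gives 280 nM. Compound 2 `CC(=O)SCC(=O)c1ccc(NS(=O)(=O)c2ccc(OC3CCCN(C)C3)cc2)nc1` carries a 1-methylpiperidin-3-yl group and gives 3700 nM. Compound 3 `CC(=O)SCC(=O)c1ccc(NS(=O)(=O)c2ccc(OC3CCN(C)CC3)cc2)nc1` carries a 1-methylpiperidin-4-yl group and gives 180 nM, the lowest of the three numbers; the step of a 1.6-fold lower number from compound 1 to compound 3 (0.19 log units; within the scatter) is within the scatter, whereas a 21-fold lower number from compound 2 to compound 3 (1.31 log units; beyond the scatter) and a 13-fold higher number from compound 1 to compound 2 (1.12 log units; beyond the scatter) are large.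

Compound 4 `CC(=O)SCC(=O)c1ccc(NS(=O)(=O)c2ccc(OCCCN3CCCC3)cc2)nc1` is the next member: 3-(pyrrolidin-1-yl)propyl in place of 1-methylpiperidin-4-yl on an oxygen on an aromatic ring. The step from compound 1 to compound 3 bears most on it, since it shows an open amine-bearing group and the ring amine giving numbers within the scatter of each other; the step from compound 2 to compound 3 warns that the ring variants can diverge strongly, but compound 4 returns to an open group. Going by the values given here, no measured step covers a pyrrolidine. The expected step of a 1.7-fold higher number from compound 3 to compound 4 (0.22 log units; within the scatter) is therefore small, most likely within the scatter, with a modest rise allowed. For compound 4 the estimate in this assay is 300 nM, within a range of 100 nM to 1000 nM.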

Compound 4, half-maximal effective concentration: 820 nM
Beside the measured number, compound 4's estimate is 2.7-fold (0.44 log units) below it, within the range that was stated.
By their numbers in this assay, from the lowest: compounds 3 and 1 (each within the scatter of the next); then compound 4; then compound 2.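

In this assay, an open chain on this oxygen no longer tracks the 1-methylpiperidin-4-yl group as closely as compound 1 did: the change to 3-(pyrrolidin-1-yl)propyl gives a 4.6-fold higher number from compound 3 to compound 4 (0.66 log units; beyond the scatter), a step beyond the scatter. Against the other open chain, pyrrolidin-1-yl in place of (dimethylamino)methyl gives a 2.9-fold higher number from compound 1 to compound 4 (0.47 log units; beyond the scatter), so a change at the far end of the chain, with the amine closed into a five-membered ring, is enough to separate two open-chain ethers. The new group also stands apart from the weaker ring ether, with a 4.5-fold lower number from compound 2 to compound 4 (0.65 log units; beyond the scatter), which places compound 4 at an intermediate level and leaves the four compounds on three separate levels, compound 3 and compound 1 sharing the lowest.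

On these data alone, a 4-(pyrrolidin-1-yl)butyl or a 3-(dimethylamino)propyl group on the same oxygen would tell the contribution of the pyrrolidine ring from that of the chain length, and that question remains open. What lies behind these steps also remains open, as nothing at hand bears on them.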